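A Third Phenyl Group Against an Assay Limit

This account rests on a few compounds, and the source may have more. Where it says the series, first, only, none or still open, it means among the compounds named here.

Compound 1 `C=C[C@]1(C)C[C@@H](OC(=O)CNC(=O)Nc2ccc(OC)cc2)[C@]2(C)[C@H](C)CC[C@]3(CCC(=O)[C@H]32)[C@@H](C)[C@@H]1O` and compound 2 `C=C[C@]1(C)C[C@@H](OC(=O)CNC(=O)Nc2cccc(Br)c2)[C@]2(C)[C@H](C)CC[C@]3(CCC(=O)[C@H]32)[C@@H](C)[C@@H]1O` share one core and differ only in the phenyl group on an amide-type nitrogen. In a functional assay on HepG2 cells (Homo sapiens) for inhibition, read by MTT assay, with a stated time of 72 h (on this read-out lower numbers stand for stronger inhibition and higher numbers for weaker inhibition), compound 1 gives > 10000 nM, which is a limit and not a number. In this assay compound 2 gives > 10000 nM, which is also a limit. Compound 2 therefore offers no measured potency to start from, and the evidence so far is the limit of > 10000 nM in this assay, at which 2 of the 2 values shown sit.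

Compound 3 `C=C[C@]1(C)C[C@@H](OC(=O)CNC(=O)Nc2ccc(F)cc2F)[C@]2(C)[C@H](C)CC[C@]3(CCC(=O)[C@H]32)[C@@H](C)[C@@H]1O` keeps the core and changes that same group: 2,4-difluorophenyl in place of 3-bromophenyl on an amide-type nitrogen. In words, 2,4-difluorophenyl stands in place of 3-bromophenyl on an amide-type nitrogen. For the measured compounds named here, one measured step bears on this change, a step that the two limits leave unreadable from compound 1 to compound 2. It is also a swap of the phenyl group on that nitrogen, but its size cannot be read. It offers no direction to carry forward, so no step beyond the usual scatter is expected in this assay. The expected step, a rough estimate, is a step that the limit leaves unreadable from compound 2 to compound 3. Most likely the assay will again report only a limit. For compound 3 the estimated value is 20000 nM, with an expected range from 8000 nM to 50000 nM.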

Compound 3, half-maximal inhibitory concentration: > 10000 nM
Compound 3 ended at the assay's limit (the forecaster's own chance of this, stated with the estimate: 85%); the middle value is on the limit's open side.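

In this assay compound 3 gives > 10000 nM as a limit and not a number. The steps among compound 1, compound 2 and compound 3 therefore cannot be read. Whether the phenyl group on that nitrogen changes potency at all in this assay stays open, and the record stands thus: the limit of > 10000 nM in this assay, at which 3 of the 3 values shown sit.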